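A few compounds are considered here, and "the series" means these few. Any claim that something is new, unique, unknown or untested is made for them only; others in the source may bear on it.

Compound 1 `COc1ccc(CN(C(=O)C=C(C)C)c2cc(OC)c(OC)c(OC)c2)cc1O` holds the lowest number of the three measured compounds in a functional assay on HCT-116 cells (Homo sapiens) for inhibition, read by MTT assay, with a stated time of 48 h (a higher number here means a weaker inhibitor, a lower number a stronger inhibitor), where compound 1 gives 290 nM. The nearest of the other two is compound 3 `COc1ccc(CNc2cc(OC)c(OC)c(OC)c2)cc1C`, which in this assay gives 60900 nM, a gap that lies well beyond the scatter of repeated measurements. Compound 2 `COc1cc(NCc2cccc(O)c2)cc(OC)c1OC` stands furthest away: in this assay compound 2 gives 67700 nM, again far beyond the scatter from compound 1. Compound 1 is thus the strongest inhibitor of the three by a wide margin.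

Compound 4 `C/C=C/C(=O)N(Cc1ccc(OC)c(O)c1)c1cc(OC)c(OC)c(OC)c1` has not yet been measured. It differs from compound 1 in one place: prop-1-en-1-yl in place of 2-methylprop-1-en-1-yl on a carbonyl carbon. The amide-type nitrogen, its substituent and the shared core are unchanged. Among the measured compounds shown here, no measured pair in this set isolates such a change, so there is no direct precedent to lean on. Given that the change is confined to the group on the carbonyl carbon, and that compound 1 gives 290 nM in this assay, compound 4 is expected to stay close, with the step of a 1.4-fold higher number from compound 1 to compound 4 (0.14 log units; within the scatter) expected to be small, possibly within the scatter. In this assay compound 4 is therefore estimated at 400 nM, with a range from 100 nM to 1600 nM.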

Compound 4, half-maximal inhibitory concentration: 55 nM
Estimate against measurement, compound 4: 7.3-fold (0.86 log units) above; measured number outside the range, below it.
By their numbers in this assay, from the lowest: compound 4; then compound 1; then compounds 3 and 2 (each within the scatter of the next).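

The group on the carbonyl carbon proves to be a position where a small edit registers: in this assay, exchanging 2-methylprop-1-en-1-yl for prop-1-en-1-yl gives a 5.3-fold lower number from compound 1 to compound 4 (0.72 log units; beyond the scatter), a modest step that lies beyond the scatter, with the entering group holding 3 heavy atoms against 4 for the one that leaves. Compound 2 and compound 3 carry no carbonyl on the nitrogen and differ from compound 1 in more than one place, so they could not isolate this position, whereas this single pair shows that the 2-methylprop-1-en-1-yl group can be replaced here without any loss in this assay. The information at hand offers no measured basis for explaining why the number moves in this direction.

On these data alone, one pair gives only one point on this position, so it remains open how a saturated propyl chain, a longer chain such as pentyl, or an amine on the carbonyl carbon would fare. As far as these compounds go, it also remains open whether the step would keep its size and direction if the rest of the shared core were changed.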